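This account rests on a few compounds, and the source may have more. Where it says the series, first, only, none or still open, it means among the compounds named here.

Working notes on the series around compound 1 `CNc1nc(N)nc2c1ncn2/C=C1/CC1(CO)CO`.

In an ADME assay on MOLT-3 cells (Homo sapiens) for cytotoxicity, with a stated time of 7 days (a lower number here means that less compound is tolerated, a higher number that more compound is tolerated), compound 1 gives > 20000 nM, which is a limit of the assay and not a number. Compound 3 `CCOc1nc(N)nc2c1ncn2/C=C1/CC1(CO)CO`, with ethoxy in place of methylamino on an aromatic carbon, likewise gives > 20000 nM in this assay, again a limit. The step that the two limits leave unreadable from compound 1 to compound 3 therefore cannot be read. Compound 2 `CC(C)CSc1nc(N)nc2c1ncn2/C=C1/CC1(CO)CO` has "not determined" (no result reported) in this assay. For the measured compounds named here, the evidence rests on (the limit of > 20000 nM in this assay, at which 2 of the 3 values shown sit), so no measured step has a readable size.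

Compound 4 `CCCCCCCCOc1nc(N)nc2c1ncn2/C=C1/CC1(CO)CO` differs from compound 1 as octyloxy in place of methylamino on an aromatic carbon. Going by the values given here, the only step with the same kind of replacement on this carbon, a step that the two limits leave unreadable from compound 1 to compound 3, is hidden by the limits, so no direction beyond the scatter is supported for this assay. It is estimated that compound 4 lies at 20000 nM, with an expected range from 5000 nM to 60000 nM. The expected change is a number no higher from compound 1 to compound 4 (the limit leaves the size open), with a fair chance that this assay again reports only a limit.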

Compound 4, half-maximal cytotoxic concentration: > 20000 nM
Compound 4 was reported as a limit; the forecaster's own chance of this, stated with the estimate: 55%; the middle value sits exactly at the limit.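

In this assay compound 4 gives > 20000 nM, which is a limit, so the steps to compound 4 from compound 1 and from compound 3 cannot be read: the limit of > 20000 nM in this assay, at which 3 of the 4 values shown sit.

The compounds shown leave open whether any replacement of methylamino on this aromatic carbon gives a readable number in this assay.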